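The source may hold more compounds than are shown below. What is called first, only, known or untested is meant among the compounds shown, and "the series" means these compounds.

In a functional assay on NCI-H460 cells (Homo sapiens) for inhibition, read by sulforhodamine B assay, with a stated time of 48 h (a higher number here means a weaker inhibitor of growth, a lower number a stronger inhibitor of growth), the measured set reads:
- compound 1 `COC(=O)c1sc2cc(-c3ccoc3)cnc2c1N`: a limit only, > 120000 nM
- compound 2 `COC(=O)c1sc2cc(-c3ccc(OC)nc3)cnc2c1N`: a limit only, > 37500 nM
- compound 3 `COC(=O)c1sc2cc(-c3ccc(OC)cc3)cnc2c1N`: a limit only, > 150000 nM

Compound 1 therefore stands at the limit of > 120000 nM in this assay, at which 1 of the 3 values shown sits; no numbered value exists in the set, the other two compounds also sitting at limits (the limit of > 37500 nM in this assay, at which 1 of the 3 values shown sits, and (the limit of > 150000 nM in this assay, at which 1 of the 3 values shown sits)). Among the measured compounds shown here, no step between measured compounds is available, so nothing shows how any change on the shared core moves the read-out.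

Compound 4 `COC(=O)c1sc2cc(-c3ccccc3N)cnc2c1N` differs from compound 1 by 2-aminophenyl in place of furan-3-yl on an aromatic carbon. With every measured compound at a limit, no step beyond the scatter is expected in this assay, and the outcome is most likely again a limit. The expected step of an at least 1.2-fold lower number from compound 1 to compound 4 (0.07 log units; that floor lies within the scatter) is none beyond the scatter. Compound 4 is estimated at 100000 nM, within 20000 nM to 300000 nM.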

Compound 4, concentration for 50% growth inhibition: 3800 nM
Compound 4: the middle estimate sits 26-fold (1.42 log units) above what was measured; measured number below the stated range.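

In this assay, this position on an aromatic carbon of the shared core can move the read-out: 2-aminophenyl in place of furan-3-yl gives an at least 31-fold lower number from compound 1 to compound 4 (1.49 log units; beyond the scatter). Among the compounds shown here, compound 4 is the only compound here with a numbered value, 3800 nM. The step is a bound and not an exact size, its starting value being a limit: the limit of > 120000 nM in this assay, at which 1 of the 4 values shown sits.

The compounds shown leave open whether the step belongs to the amino group or to the carbon-only ring. Plain phenyl, or a hydroxyl in place of the amine, would help separate these.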